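Methoxy for fluoro on the aryl ring of compound 2

The compounds below may be only part of what the source reports. "The series", "measured", "known", "first", "only" and "open" are said of these compounds alone.

Of the compounds shown here, two of a shared core have been measured in a functional assay on ACHN cells (Homo sapiens) for cytotoxicity, read by MTT assay, with a stated time of 48 h; a higher number here means a weaker inhibitor, a lower number a stronger inhibitor. Compound 1, `COc1ccc(-c2cc(C(=O)Nc3nc4ccc(Cl)cc4s3)nc3cc(-c4ccccc4)nn23)cc1`, gives 7240 nM in this assay. Within the data shown here, compound 2, `COc1ccc2nc(NC(=O)c3cc(-c4ccc(F)cc4)n4nc(-c5ccccc5)cc4n3)sc2c1`, gives 26300 nM, the higher of the two numbers and beyond the scatter from compound 1; it stands as the weaker inhibitor of the pair, with no single-point step connecting the two structures.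

Compound 3, `COc1ccc(-c2cc(C(=O)Nc3nc4ccc(OC)cc4s3)nc3cc(-c4ccccc4)nn23)cc1`, is not yet measured. It is reached from compound 2 by one change: methoxy in place of fluoro on an aromatic carbon. Among the measured compounds shown here, no measured pair shows this change, so the size of the step is unknown. For the measured compounds named here, the 4-methoxyphenyl group that enters is the one compound 1 also carries, and compound 1 gives 7240 nM, so a move toward a lower number appears plausible, though compound 3 differs from compound 1 elsewhere on the core and no step between those two is available. The expected step from compound 2 to compound 3 is therefore a modest one downward, roughly at the edge of the scatter: a 2.2-fold lower number from compound 2 to compound 3 (0.34 log units; beyond the scatter). For compound 3 the estimate in this assay is 12000 nM, with a range from 4000 nM to 35000 nM.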

Compound 3, half-maximal inhibitory concentration: 38300 nM
Compound 3: the middle estimate sits 3.2-fold (0.50 log units) below what was measured; the measured number lies above the stated range.
By their numbers in this assay, from the lowest: compound 1; then compounds 2 and 3 (each within the scatter of the next).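

In this assay, placing methoxy instead of fluoro on the aromatic carbon para to a large group, the change from 4-fluorophenyl to 4-methoxyphenyl, gives a 1.5-fold higher number from compound 2 to compound 3 (0.16 log units; within the scatter), so this assay does not tell the two groups apart at this position when methoxy stands at the other varied place. The other change, where chloro gives way to methoxy with the 4-methoxyphenyl group kept, gives a 5.3-fold higher number from compound 1 to compound 3 (0.72 log units; beyond the scatter), the only step of the pair that lies beyond the scatter, so among these three compounds a difference that can be read appears at that second place and not at the aryl group. Nothing available gives a reason for either step.

On these data alone, each of the two changes has been read only once, so it remains open whether 4-fluorophenyl and 4-methoxyphenyl would still not be told apart with chloro at the other place. Also open, as far as these compounds go, is how an amine or a carboxylic acid on the aryl ring, or a longer chain such as ethoxy in place of methoxy, would read in this assay.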